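Compound 1 and its furan counterpart, compound 4

This account rests on a few compounds, and the source may have more. Where it says the series, first, only, none or still open, it means among the compounds named here.

Measured in a functional assay on NCI-H460 cells (Homo sapiens) for cytotoxicity, read by MTT assay, with a stated time of 72 h; a higher number here means a weaker inhibitor, a lower number a stronger inhibitor:
- compound 1 `CC(C)(C)c1[nH]cnc1/C=c1\[nH]c(=O)/c(=C/c2cccc(C(=O)c3ccc(F)cc3)c2)[nH]c1=O` gives 3.8 nM
- compound 2 `CC(C)(C)c1[nH]cnc1/C=c1\[nH]c(=O)/c(=C/c2cccc(Oc3ccc(F)cc3)c2)[nH]c1=O` gives 4 nM
- compound 3 `O=c1[nH]/c(=C\c2ccco2)c(=O)[nH]/c1=C\c1cccc(Oc2ccc(F)cc2)c1` gives 155 nM

Compound 1 and compound 2 share the low end of these three numbers, within the scatter of each other, while compound 3 stands well clear of them. The open question concerns compound 4 `COCc1ccc(/C=c2\[nH]c(=O)/c(=C/c3cccc(C(=O)c4ccc(F)cc4)c3)[nH]c2=O)o1`, which has not yet been measured. Its difference from compound 1 is 5-(methoxymethyl)furan-2-yl in place of 5-(tert-butyl)-1H-imidazol-4-yl on a double-bonded chain carbon bound to an aromatic carbon, and it amounts to 5-(methoxymethyl)furan-2-yl in place of 5-(tert-butyl)-1H-imidazol-4-yl on a double-bonded chain carbon bound to an aromatic carbon.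

The closest measured precedent is a 39-fold higher number from compound 2 to compound 3 (1.59 log units; beyond the scatter), a large step for furan-2-yl replacing the same group at the same place. The other measured step, a 1.1-fold higher number from compound 1 to compound 2 (0.02 log units; within the scatter), exchanges (4-fluorophenyl)carbonyl for 4-fluorophenoxy and stays within the scatter, so the large step can reasonably be carried over to the carbonyl-bearing compounds. Going by the values given here, no measured compound carries the methoxymethyl group, which leaves its contribution unknown and the range wide.

A large rise in the number is therefore expected, and the estimated step is a 39-fold higher number from compound 1 to compound 4 (1.60 log units; beyond the scatter) in this assay. Compound 4 is expected to give about 150 nM, with an estimated range from 45 nM to 500 nM in this measurement.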

Compound 4, half-maximal inhibitory concentration: 2.9 nM
Compound 4: middle estimate off by 52-fold (1.71 log units), on the high side; measured number outside the range, below it.
By their numbers in this assay, from the lowest: compounds 4, 1 and 2 (each within the scatter of the next); then compound 3.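

In this assay, the 5-(tert-butyl)-1H-imidazol-4-yl group on a double-bonded chain carbon bound to an aromatic carbon gives way to 5-(methoxymethyl)furan-2-yl with a 1.3-fold lower number from compound 1 to compound 4 (0.12 log units; within the scatter), so a furan ring at this place can match the imidazole compound within the scatter. Going by these compounds alone, the large rise seen earlier, a 39-fold higher number from compound 2 to compound 3 (1.59 log units; beyond the scatter), is therefore not a fixed price of replacing that imidazole with a furan, although compound 3 and compound 4 differ in two places, the methoxymethyl group and the exchange of 4-fluorophenoxy for (4-fluorophenyl)carbonyl, so no single step links them. Nothing measured here explains why the two replacements end so differently.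

The compounds shown leave open whether the methoxymethyl group, the (4-fluorophenyl)carbonyl group or the two together separate compound 4 from compound 3. They also leave open how far the low number depends on the methoxymethyl group itself, since no furan here carries a hydroxymethyl group, an aminomethyl group or a carboxylic acid in its place.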